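The source may hold more compounds than are shown below. What is called first, only, known or untested is meant among the compounds shown, and "the series" means these compounds.

In an ADME assay for pharmacokinetics (a higher number here means that the compound lasts longer, a lower number that the compound disappears faster), compound 1 `CCOc1ccc(-n2nnc3c(C(N)=O)ncn3c2=O)cc1` gives 1.3 h. Compound 3 `Cc1ccc(-n2nnc3c(C(N)=O)ncn3c2=O)cc1` gives 0.667 h, a value the scatter does not separate from that of compound 1, while compound 2 `NC(=O)c1ncn2c(=O)n(-c3cccc4ccccc34)nnc12` gives 0.0767 h, well under both. Compound 4 `NC(=O)c1ncn2c(=O)n(-c3ccc(Cl)cc3)nnc12`, not yet measured, keeps the shared core and carries one change from compound 1: chloro in place of ethoxy on an aromatic carbon. In words, this is chloro in place of ethoxy on an aromatic carbon, para to a large group.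

Among the compounds with values here, one measured step bears directly on this change, since it replaces the same ethoxy with methyl: a 1.9-fold lower number from compound 1 to compound 3 (0.29 log units; within the scatter). Compound 2 differs from compound 1 by more than a single group and offers no clean comparison. Within the data shown here, with only that one step as a guide, a modest drop in this assay is expected, one that probably stays within the scatter. The estimate for compound 4 is 0.8 h, with an expected range of 0.35 h to 1.8 h. The expected change is a 1.6-fold lower number from compound 1 to compound 4 (0.21 log units; within the scatter).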

Compound 4, half-life: 0.105 h
Beside the measured number, compound 4's estimate is 7.6-fold (0.88 log units) above it, and the stated range ends above it.
By their numbers in this assay, from the lowest: compounds 2 and 4 (each within the scatter of the next); then compounds 3 and 1 (each within the scatter of the next).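

In this assay, the place on the aromatic ring para to a large group proves sensitive to which group sits there: chloro in place of ethoxy gives a 12-fold lower number from compound 1 to compound 4 (1.09 log units; beyond the scatter), whereas methyl in place of ethoxy gave only a 1.9-fold lower number from compound 1 to compound 3 (0.29 log units; within the scatter). Chloro in place of methyl at the same place gives a 6.4-fold lower number from compound 3 to compound 4 (0.80 log units; beyond the scatter), so among these three compounds the large drop goes with chloro and not with the loss of ethoxy alone. Nothing available accounts for this drop.

The compounds shown leave open whether the drop is particular to chloro or would recur with fluoro, an amine or a longer ether such as propoxy. On these data alone, every single-place comparison here sits at this one place on the ring, and how the same changes would behave elsewhere on it remains unknown.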